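Series notes: from compound 3 to compound 4

A few compounds are considered here, and "the series" means these few. Any claim that something is new, unique, unknown or untested is made for them only; others in the source may bear on it.

Measured compounds:
compound 1 `COc1nn(C)c2cccc(NS(=O)(=O)c3cccc(Cl)c3Cl)c12`, 794 nM
compound 2 `Cn1ncc2c(NS(=O)(=O)c3cccc(Cl)c3Cl)ncnc21`, 1260 nM
compound 3 `COc1nn(C)c2nc(C)nc(NS(=O)(=O)c3cccc(Cl)c3Cl)c12`, 631 nM

In a functional assay on cells for antagonist activity at C-C chemokine receptor type 4 (Homo sapiens), read by GTPgammaS binding (on this read-out lower numbers stand for stronger inhibition and higher numbers for weaker inhibition), compound 3 gives 631 nM, the lowest of the three numbers; compound 1 at 794 nM and compound 2 at 1260 nM both lie within the scatter of it, so no order among the three can be claimed. Compound 4 `COc1nn(C)c2nc(NC3COC3)nc(NS(=O)(=O)c3cccc(Cl)c3Cl)c12` is not yet measured. It differs from compound 3 in one place: (oxetan-3-yl)amino in place of methyl on an aromatic carbon. Among the compounds with values here, no measured pair shows a change of this kind, so the size of the step has no precedent here. The expected step in this assay is a 1.4-fold lower number from compound 3 to compound 4 (0.15 log units; within the scatter), small, more likely towards a lower number than a higher one, and possibly none beyond the scatter. Compound 4 is expected to give 450 nM, within a range from 130 nM to 1600 nM.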

Compound 4, half-maximal inhibitory concentration: 10000 nM
Compound 4: middle estimate off by 22-fold (1.35 log units), on the low side, and the stated range ends below it.
By their numbers in this assay, from the lowest: compounds 3, 1 and 2 (each within the scatter of the next); then compound 4.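

The aromatic carbon between two ring nitrogen atoms proves sensitive to substitution: in this assay, (oxetan-3-yl)amino in place of methyl gives a 16-fold higher number from compound 3 to compound 4 (1.20 log units; beyond the scatter). The earlier compounds shown here, with no pair differing in one place, could not show this. The change brings in a four-membered ring, a hydrogen-bond donor and hydrogen-bond acceptors together, and this single step does not separate them. No data here bear on the cause of the step. Open, from the compounds shown here alone, is whether a smaller group such as methylamino, or a cyclobutylamino group without the ring oxygen, gives a step of similar size.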